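The compounds below may be only part of what the source reports. "The series", "measured", "known", "first", "only" and "open" are said of these compounds alone.

Two compounds of this series have measured numbers in a functional assay on HeLa cells (Homo sapiens) for cytotoxicity, read by MTT assay, with a stated time of 72 h, tested at 1 uM; on this read-out higher numbers stand for more inhibition of growth at the one concentration tested and lower numbers for less inhibition of growth. Compound 1 `N/C(=N\NC(=S)N1CCCC1)c1ccc(F)cn1` gives 62.8% in this assay, and this is the higher of the two values. Compound 2 `Cc1cccc(/C(N)=N/NC(=S)N2CCSCC2)n1` gives 46.5% in this assay, a number that lies beyond the usual scatter below that of compound 1; as compound 2 differs from compound 1 in more than one place, no single change can be tied to that gap.

Compound 3 `N/C(=N\NC(=S)N1CCOCC1)c1ccc(F)cn1` has not yet been measured. It differs from compound 1 in one place: morpholin-4-yl in place of pyrrolidin-1-yl on a thiocarbonyl carbon. Within the data shown here, no pair of measured compounds shows this change, so the size of its effect is unknown. The two measured values show that a six-membered ring with two hetero atoms on the thiocarbonyl carbon went together with a lower number in compound 2, but that compound also carries a different core, so the comparison is loose. A moderate drop from compound 1 to compound 3 in this assay is expected, a number 12.8 percentage points lower from compound 1 to compound 3 (beyond the scatter). Compound 3 is estimated at 50% in this assay, within a range from 30% to 68%.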

Compound 3, percent growth inhibition at one concentration: 21.4%
Compound 3: the middle estimate sits 28.6 percentage points above what was measured; measured number below the stated range.
By their numbers in this assay, from the lowest: compound 3; then compound 2; then compound 1.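

In this assay, morpholin-4-yl in place of pyrrolidin-1-yl on a thiocarbonyl carbon gives a number 41.4 percentage points lower from compound 1 to compound 3 (beyond the scatter), a large step. Among these compounds, compound 1 and compound 3 differ in this one place and share the rest of their structure, so this pair shows for the first time that the ring at this position can by itself change the read-out strongly. The step comes with several changes at once, as a five-membered non-aromatic ring with 1 hetero atom gives way to a six-membered one with 2 hetero atoms and a hydrogen-bond acceptor enters, and no measurement here explains why the number falls.

The compounds shown leave open whether the larger ring, the added oxygen or both go with the drop, and a piperidin-1-yl group on the same thiocarbonyl carbon of the core of compound 1 would help to separate these, as it has a six-membered ring with carbon in place of that oxygen. They also leave open how an open-chain amine such as dimethylamino would read at this position.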